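Shortening an Ether Chain on a Pyridine Core

A few compounds are considered here, and "the series" means these few. Any claim that something is new, unique, unknown or untested is made for them only; others in the source may bear on it.

Measured so far:
Compound 1 `C/C=C\Oc1cncc(N2CCCNCC2)c1`: 45%
Compound 2 `Clc1cncc(N2CCNCC2)c1`: 41%

Of the compounds shown here, two have been tested in an assay on HEK293 cells with Neuronal acetylcholine receptor; alpha4/beta2 (Homo sapiens) as the target, read by FLIPR and calcium flux; a higher number here means a larger maximal response, a lower number a smaller maximal response. Compound 1 gives 45% in this assay, and compound 2 gives 41%. The gap between these two numbers lies within the usual scatter of repeated measurements, so neither compound can be set above the other; compound 1 simply sits alongside compound 2 at a middling maximal response.

The next compound to be measured is compound 3 `C=COc1cncc(N2CCCNCC2)c1`. It arises from compound 1 by a small change: vinyl in place of prop-1-en-1-yl on an oxygen on an aromatic ring. The chain is trimmed while the oxygen link and the core stay as they are.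

Among the compounds with values here, no measured pair isolates such a trimming. In this assay the expected step is a number 2 percentage points lower from compound 1 to compound 3 (within the scatter), an estimated small movement that could go in either direction and is not expected to reach beyond the scatter. Compound 3 is therefore expected to give about 43%, within a range from 25% to 60%.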

Compound 3, largest response reached (reported as efficacy), in percent of the reference or control that the assay uses: 61%
The estimate for compound 3 lay 18 percentage points below the measured number, and the stated range ends below it.
By their numbers in this assay, from the lowest: compounds 2 and 1 (each within the scatter of the next); then compound 3.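

In this assay the swap of vinyl for prop-1-en-1-yl on an oxygen on an aromatic ring gives a number 16 percentage points higher from compound 1 to compound 3 (beyond the scatter) and this shows that the maximal response is sensitive to the group at this place, even when the change is small. The two groups match in what is counted here, with no ring, no net charge, no hydrogen-bond donors or acceptors, and 1 double bond outside aromatic rings each; the count that differs is heavy atoms, 2 for vinyl and 3 for prop-1-en-1-yl. No measurement at hand explains why the response changes with this swap.

On these data alone, it remains open whether a still smaller group such as methyl would raise the response further, and whether ethyl, which has no double bond, would keep it. A single pair also cannot show how a longer chain such as butyl would behave at this oxygen.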